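The source may hold more compounds than are shown below. What is called first, only, known or untested is meant among the compounds shown, and "the series" means these compounds.

Three compounds have been measured in a functional assay on BGC-823 cells (Homo sapiens) for inhibition, read by MTT assay, with a stated time of 72 h; on this read-out higher numbers stand for weaker inhibition and lower numbers for stronger inhibition:

Compound 1 `O=C1Nc2ccccc2/C1=C\C(=O)c1cccc(Cl)c1`: 7700 nM
Compound 2 `O=C1Nc2ccccc2/C1=C\C(=O)c1ccccc1F`: 11800 nM
Compound 3 `Nc1cccc(C(=O)/C=C2/C(=O)Nc3ccccc32)c1`: 29900 nM

Compound 2, at 11800 nM, cannot be told apart from compound 1, at 7700 nM, since the two values lie within the scatter of each other. Compound 3, at 29900 nM, stands beyond the scatter above compound 2.

The next compound is compound 4 `O=C1Nc2ccccc2/C1=C\C(=O)c1ccccc1Br`, which has not yet been measured. It differs from compound 2 by bromo in place of fluoro on an aromatic carbon, ortho to a large group: bromo in place of fluoro on an aromatic carbon.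

Within the data shown here, only one measured step is available as a guide, and it bears on this change only loosely. That step, a 3.9-fold higher number from compound 1 to compound 3 (0.59 log units; beyond the scatter), is modest and exchanges chloro for amino, so it does not compare like with like. More useful is that compound 1, which carries chloro, and compound 2, which carries fluoro, sit within the scatter of each other, although the group also sits differently in the two. Among the measured compounds shown here, no bromo compound has been measured.

In this assay, no step beyond the scatter is therefore expected. The expected step is a 1.2-fold lower number from compound 2 to compound 4 (0.09 log units; within the scatter). For compound 4 the estimated value is 9500 nM, with an expected range from 4000 nM to 22000 nM.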

Compound 4, half-maximal inhibitory concentration: 9500 nM
Estimate against measurement, compound 4: no gap at the digits printed, and the stated range covers the measured number.
By their numbers in this assay, from the lowest: compounds 1, 4 and 2 (each within the scatter of the next); then compound 3.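

In this assay, a 1.2-fold lower number from compound 2 to compound 4 (0.09 log units; within the scatter) when bromo takes the place of fluoro on an aromatic carbon, ortho to a large group. The earlier compounds shown here offered only a loose comparison between chloro and fluoro, whose places differ, whereas this pair exchanges one halogen for another at the same place on the shared core, with one heavy atom leaving, one entering, and no hydrogen-bond donor or acceptor on either side. At this position, then, the exchange of fluoro for bromo gives no difference that can be told from the scatter, and nothing at hand offers an explanation for this result.

The compounds shown leave open whether a group of another kind at this same position, such as an amine, a methoxy group or a carboxylic acid, would also stay within the scatter of compound 2. They also leave open whether the same exchange of fluoro for bromo would give a similarly small step on other carbons of this ring, or on a different core.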